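A few compounds are considered here, and "the series" means these few. Any claim that something is new, unique, unknown or untested is made for them only; others in the source may bear on it.

Of the compounds shown here, three sharing one core have been measured in a physicochemical assay for acid dissociation. Compound 1 `FC(F)(F)c1ccc(-c2ccc3c(NCCCNCc4ccco4)ccnc3c2)cc1` gives 9.47. Compound 2 `COc1cccc(Oc2ccc3c(NCCCNCc4ccco4)ccnc3c2)c1` gives 9.28. Compound 3 `CC(C)CCc1ccc2c(NCCCNCc3ccco3)ccnc2c1` gives 9.47, which leaves it level with compound 1 at the digits recorded and, together with compound 1, at the top of the three numbers, though all three lie within the scatter of one another: the step of no change at the digits printed from compound 1 to compound 3 (within the scatter), the step of a number 0.19 log units higher from compound 2 to compound 3 (within the scatter) and the step of a number 0.19 log units lower from compound 1 to compound 2 (within the scatter) all fall inside it.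

Compound 4 `COc1ccccc1Oc1ccc2c(NCCCNCc3ccco3)ccnc2c1` has not yet been measured. It differs from compound 3 in one place: 2-methoxyphenoxy in place of isopentyl on an aromatic carbon. The step that bears most directly on this change is a number 0.19 log units higher from compound 2 to compound 3 (within the scatter), which runs the opposite way and involves a 3-methoxyphenoxy group rather than the 2-methoxyphenoxy group entering here. The steps of a number 0.19 log units lower from compound 1 to compound 2 (within the scatter) and no change at the digits printed from compound 1 to compound 3 (within the scatter) point the same way. None of these moved beyond the scatter, so only a small downward drift, if any, is expected. In this assay the expected step for compound 4 is a number 0.12 log units lower from compound 3 to compound 4 (within the scatter). Compound 4 is therefore estimated at 9.35, within a range from 9.1 to 9.6.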

Compound 4, acid dissociation constant: 9.28
Beside the measured number, compound 4's estimate is 0.07 log units above it; the measured number falls inside the stated range.
By their numbers in this assay, from the lowest: compounds 2, 4, 1 and 3 (each within the scatter of the next).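

In this assay 2-methoxyphenoxy on this aromatic carbon stays within the scatter of both groups it can be set against, with the step of a number 0.19 log units lower from compound 3 to compound 4 (within the scatter) against isopentyl and the step of a number 0.19 log units lower from compound 1 to compound 4 (within the scatter) against 4-(trifluoromethyl)phenyl. Among these compounds, the earlier compounds held only one methoxyphenoxy group, and the second one now adds a comparison inside that family: 2-methoxyphenyl in place of 3-methoxyphenyl on the oxygen gives the step of no change at the digits printed from compound 2 to compound 4 (within the scatter). Across these four compounds, then, neither the kind of group at this position nor the place of the methoxy on the phenoxy ring carries the number beyond the scatter, which extends what the first three compounds showed to a further ether-linked group.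

Nothing in the data accounts for why the numbers stay so close together. Still open, as far as these compounds go, is whether a group of another kind at this position, such as a primary amine or a carboxylic acid, would take the number beyond the scatter, and whether a change elsewhere on the shared core, such as a longer chain between the two nitrogens, would do so.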